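Ethyl in Place of Propanoyl: An Expected Stability Step

The source may hold more compounds than are shown below. What is called first, only, known or untested is meant among the compounds shown, and "the series" means these compounds.

Of the compounds shown here, two have so far been measured in an ADME assay on microsomes from liver (Macaca mulatta) for metabolic stability, with a stated time of 0.5 h, tested at 0.5 mg/mL; a lower number here means that less of the compound is left, a higher number that more of the compound is left. Compound 1, `CCC(=O)N1CC2(CC(NC(=O)c3cc(-c4ccccc4)no3)C2)C1`, gives 69% in this assay, the highest of the two numbers seen. Compound 2, `CC(CNC(=O)c1cc(-c2ccc(F)cc2)no1)C(=O)N(C)C`, gives 52% in this assay, a number that lies beyond the usual scatter below that of compound 1. These two compounds do not differ in a single place, so their values are taken only as they stand: compound 1 retains more than compound 2.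

The next compound, compound 3, `CCN1CC2(CC(NC(=O)c3cc(-c4ccccc4)no3)C2)C1`, is set against compound 1. The change is ethyl in place of propanoyl on an amine nitrogen in a ring. No step between measured compounds resembles this one, so the account has only compound 1 to reason from. The expectation is that compound 3 leaves less remaining than compound 1 in this assay, by a step of moderate size, somewhat beyond the scatter and in the downward direction, though a result within the scatter of compound 1 would not be surprising. Compound 3 is therefore expected to give 55% in this assay, within a range from 35% to 75%. That estimate means an expected step of a number 14 percentage points lower from compound 1 to compound 3 (beyond the scatter).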

Compound 3, percent of the compound remaining: 87%
For compound 3 the middle estimate is 32 percentage points below the measured one; the measured number lies above the stated range.
By their numbers in this assay, from the lowest: compound 2; then compound 1; then compound 3.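

Going by these compounds alone, this is the first step where only one place changes, and in this assay it runs upward: ethyl in place of propanoyl on the amine nitrogen in a ring gives a number 18 percentage points higher from compound 1 to compound 3 (beyond the scatter). At this position, then, the carbonyl of propanoyl is not required for a high percentage of compound remaining, and the smaller ethyl group, with no hydrogen-bond acceptor, is accommodated with a gain rather than a loss. No measurement shown here offers an explanation for the rise, so it stands as an observation on this one pair.

A single pair cannot separate the removal of the carbonyl from the shortening of the group: propyl on the same nitrogen would keep the chain length without the carbonyl, whereas acetyl would keep the carbonyl on a shorter chain. As far as these compounds go, it also remains open whether the step would hold with methyl or a cyclic amide at this nitrogen, or with a fluorine on the phenyl ring of the shared core, as well as in microsomes from another species.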